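A Trifluorophenyl Swap Against a Cytotoxicity Limit

This account rests on a few compounds, and the source may have more. Where it says the series, first, only, none or still open, it means among the compounds named here.

Of the compounds shown here, three have been tested so far, and none has yielded a number. In a functional assay on HFF cells (Homo sapiens) for cytotoxicity (on this read-out higher numbers stand for weaker inhibition and lower numbers for stronger inhibition), compound 1 `COc1ccc(S(=O)(=O)NN2C(=S)S/C(=C\c3ccc(Cl)c(Cl)c3)C2O)cc1` gives > 100000 nM as a limit of the assay. In this assay compound 2 `O=C1/C(=C/c2ccc(C(F)(F)F)cc2)SC(=S)N1NS(=O)(=O)c1ccccc1` gives > 100000 nM as a limit too. In this assay compound 3 `O=C1/C(=C/c2ccc(Cl)c(F)c2)SC(=S)N1NS(=O)(=O)c1ccccc1` gives > 100000 nM as a limit as well. For the measured compounds named here, compound 3 therefore stands where the other two stand, and the whole series so far comes down to one observation: the limit of > 100000 nM in this assay, at which 3 of the 3 values shown sit, and nothing more.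

Compound 4 `O=C1/C(=C/c2cc(F)c(F)cc2F)SC(=S)N1NS(=O)(=O)c1ccccc1` has not yet been measured. Its structural change from compound 3 is 2,4,5-trifluorophenyl in place of 4-chloro-3-fluorophenyl on a double-bonded chain carbon bound to a double-bonded ring carbon and amounts to 2,4,5-trifluorophenyl in place of 4-chloro-3-fluorophenyl on a double-bonded chain carbon bound to a double-bonded ring carbon. Going by the values given here, no measured pair differs in one place only, so the size of this change cannot be read directly from the data. Even so, no step beyond the usual scatter is expected in this assay in either direction. That expectation rests on compound 3 and its limit of > 100000 nM in the same assay. The estimated step of a number no higher from compound 3 to compound 4 (the limit leaves the size open) is accordingly expected to stay within the scatter. Compound 4 is expected at 100000 nM with an estimated range from 40000 nM to 200000 nM in this read-out.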

Compound 4, half-maximal inhibitory concentration: > 100000 nM
Compound 4: no number, only a limit (the forecaster's own chance of this, stated with the estimate: 80%); the middle value sits exactly at the limit.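

In this assay, for the compounds shown here, compound 3 and compound 4 both stand at a limit, so no step between them can be read. The series still comes down to one observation: the limit of > 100000 nM in this assay, at which 4 of the 4 values shown sit.

The compounds shown leave open at what concentration any of them would give an actual number, and whether exchanging these groups would change it.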